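This account rests on a few compounds, and the source may have more. Where it says the series, first, only, none or still open, it means among the compounds named here.

Measured compounds:
- compound 1, `Nc1ccccc1NC(=O)c1ccc(CSC(=S)N2CCCc3ccccc32)cc1`: 38.5%
- compound 2, `CN(Cc1ccncc1)C(=S)SCc1ccc(C(=O)Nc2ccccc2N)cc1`: 38.1%
- compound 3, `Nc1ccccc1NC(=O)c1ccc(CSC(=S)N2CCc3cc(Cl)ccc32)cc1`: 57.7%

In a functional assay on MGC-803 cells (Homo sapiens) for antiproliferative activity, read by CCK-8 assay, with a stated time of 72 h, tested at 2 uM (a higher number here means a stronger effect of the compound at the concentration tested, a lower number a weaker effect), compound 3 stands highest of the three, compound 1 and compound 2 both being lower beyond the scatter. Compound 4, `CN(C(=S)SCc1ccc(C(=O)Nc2ccccc2N)cc1)c1cccnc1`, is not yet measured. Its change from compound 3 is methyl(pyridin-3-yl)amino in place of 5-chloro-2,3-dihydro-1H-indol-1-yl on a thiocarbonyl carbon. The closest measured step runs the other way: a number 19.6 percentage points higher from compound 2 to compound 3 (beyond the scatter), where a related methyl-pyridinylmethyl-bearing amine gave way to the same indolinyl group. Undoing that kind of exchange should undo much of that gain, so a modest fall in this assay is expected. The estimate for compound 4 is therefore 38%, within 25% to 52%, meaning an expected step of a number 19.7 percentage points lower from compound 3 to compound 4 (beyond the scatter).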

Compound 4, a percentage reported as inhibition, at one concentration (the size of the read-out at that concentration, not a potency): 46.1%
Compound 4: middle estimate off by 8.1 percentage points, on the low side, and the stated range covers the measured number.
By their numbers in this assay, from the lowest: compounds 2, 1 and 4 (each within the scatter of the next); then compound 3.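

Swapping 5-chloro-2,3-dihydro-1H-indol-1-yl for methyl(pyridin-3-yl)amino on the thiocarbonyl carbon gives a number 11.6 percentage points lower from compound 3 to compound 4 (beyond the scatter) in this assay, so a second pyridine-bearing group also stays short of compound 3. The other two steps, a number 8 percentage points higher from compound 2 to compound 4 (within the scatter) and a number 7.6 percentage points higher from compound 1 to compound 4 (within the scatter), are both within the scatter, so compound 4 cannot be separated from compound 1 or compound 2. Nothing available explains these differences. Still open, on these data alone, is whether the chlorine matters: a fluorine or a hydrogen in its place on the same ring would test that.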